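This account rests on a few compounds, and the source may have more. Where it says the series, first, only, none or still open, it means among the compounds named here.

Compound 1 `O=S(=O)(c1cccc2ncccc12)n1cc(C2=CCNCC2)c2cc(Cl)ccc21` gives 11 nM in an assay on HEK293 cells for displacement of a labelled ligand from 5-hydroxytryptamine receptor 6 (Homo sapiens), read by scintillation counting; on this read-out higher numbers stand for weaker inhibition and lower numbers for stronger inhibition.
Compound 2 `COc1ccc2c(c1)c(C1=CCNCC1)cn2S(=O)(=O)c1cnc2ccccc2c1` gives 8 nM in this assay.
Compound 3 `COc1ccc2c(c1)c(C1=CCNCC1)cn2S(=O)(=O)c1cccc2ncccc12` gives 4 nM in this assay.

Among the compounds with values here, compound 3 shows the lowest number of the three, yet only the step of a 2.8-fold lower number from compound 1 to compound 3 (0.44 log units; beyond the scatter) lies beyond the scatter; the step of a 2.0-fold lower number from compound 2 to compound 3 (0.30 log units; within the scatter) does not, so compound 2 and compound 3 cannot be told apart. Compound 4 `COc1ccc2c(c1)c(C1=CCNCC1)cn2S(=O)(=O)c1ccc2ncccc2c1` has not yet been measured. It differs from compound 3 by quinolin-6-yl in place of quinolin-5-yl on a sulfonyl sulfur. Within the data shown here, the one measured step of the same kind, a swap of one quinolinyl group for another on the sulfonyl sulfur, is a 2.0-fold lower number from compound 2 to compound 3 (0.30 log units; within the scatter), which stayed within the scatter. A step no larger than the scatter is therefore expected here, the estimate being a 1.5-fold higher number from compound 3 to compound 4 (0.18 log units; within the scatter). Compound 4 is expected to give 6 nM in this assay, within a range from 2.5 nM to 15 nM.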

Compound 4, inhibition constant: 14 nM
Compound 4: middle estimate off by 2.3-fold (0.37 log units), on the low side, and the stated range covers the measured number.
By their numbers in this assay, from the lowest: compounds 3, 2, 1 and 4 (each within the scatter of the next, the first and the last beyond it).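

In this assay, swapping one quinolinyl group for another on the sulfonyl sulfur can move the number beyond the scatter, as a 3.5-fold higher number from compound 3 to compound 4 (0.54 log units; beyond the scatter) shows, even though the two groups hold the same atoms. With a 1.8-fold higher number from compound 2 to compound 4 (0.24 log units; within the scatter) the step stays within the scatter, so quinolin-3-yl cannot be told apart from quinolin-6-yl or from quinolin-5-yl; only the latter two differ. No evidence here bears on why these groups differ. Still open, on these data alone, is whether the step between quinolin-5-yl and quinolin-6-yl holds with chloro in place of methoxy, and how a plain phenyl on the sulfonyl sulfur would compare.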